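The source may report more compounds than this note shows. Statements on the series, on what has been measured and on what is new or still open speak of the compounds shown alone.

Among the compounds with values here, compound 2 `CCCN(CC[C@H]1CC[C@H](NC(=O)c2cccc3ncccc23)CC1)[C@H]1CCc2nc(N)sc2C1` gives 1.6 nM in an assay on brain for displacement of a labelled ligand from D(3) dopamine receptor (Rattus norvegicus) (on this read-out lower numbers stand for stronger inhibition and higher numbers for weaker inhibition), the lowest of the two numbers measured; the only other point is compound 1 `CCCN(CC[C@H]1CC[C@H](NC(=O)/C=C/c2ccc(OC)cc2)CC1)[C@H]1CCc2nc(N)sc2C1`, which gives 6.7 nM in this assay, the change being a 4.2-fold lower number from compound 1 to compound 2 (0.62 log units; beyond the scatter). Compound 3 `CCCN(CC[C@H]1CC[C@H](NC(=O)c2cccc(-n3ccnc3)c2)CC1)[C@H]1CCc2nc(N)sc2C1` differs from compound 2 by 3-(1H-imidazol-1-yl)phenyl in place of quinolin-5-yl on a carbonyl carbon. That single earlier step is the only one touching the same carbonyl carbon, and it was modest, so for compound 3 the expected change in this assay is a small rise of about a 2.5-fold higher number from compound 2 to compound 3 (0.40 log units; beyond the scatter). Compound 3 is therefore estimated at 4 nM, within 1.3 nM to 13 nM.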

Compound 3, inhibition constant: 1.1 nM
For compound 3 the middle estimate is 3.6-fold (0.56 log units) above the measured one; measured number outside the range, below it.
By their numbers in this assay, from the lowest: compounds 3 and 2 (each within the scatter of the next); then compound 1.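

On the carbonyl carbon, 3-(1H-imidazol-1-yl)phenyl and quinolin-5-yl are not told apart in this assay, with a 1.5-fold lower number from compound 2 to compound 3 (0.16 log units; within the scatter), so a five-membered aromatic ring with 2 hetero atoms can take the place of the ring pair of quinolin-5-yl without a readable shift. Relative to 2-(4-methoxyphenyl)ethenyl, the new group gives a 6.1-fold lower number from compound 1 to compound 3 (0.78 log units; beyond the scatter), in the same direction as the earlier step to quinolin-5-yl. No outside evidence bears on this result. Still open, from the compounds shown here alone, is how a plain phenyl, or a phenyl carrying an amine or a carboxylic acid, would read on the same carbonyl carbon in this assay.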